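From 3-Methylphenyl to 2-Fluorophenyl on the Shared Core

A few compounds are considered here, and "the series" means these few. Any claim that something is new, unique, unknown or untested is made for them only; others in the source may bear on it.

Compound 1 `Cc1ccccc1-n1cc(-c2ccc(/C=C3\C(=O)Nc4ccccc43)cc2)nn1`: 9770 nM
Compound 2 `Cc1cccc(-n2cc(-c3ccc(/C=C4\C(=O)Nc5ccccc54)cc3)nn2)c1`: 4690 nM
Compound 3 `Cc1cccc(-n2cc(-c3ccc(/C=C4\C(=O)Nc5ccc(F)cc54)cc3)nn2)c1`: 6810 nM

These three compounds were tested in a functional assay on MKN-45 cells (Homo sapiens) for inhibition, read by CCK-8 assay, with a stated time of 24 h; a lower number here means a stronger inhibitor, a higher number a weaker inhibitor. There, compound 3 gives 6810 nM, a number within the usual scatter of those of both other compounds. The next compound to be tested is compound 4 `O=C1Nc2ccc(F)cc2/C1=C/c1ccc(-c2cn(-c3ccccc3F)nn2)cc1`. The change is 2-fluorophenyl in place of 3-methylphenyl on an aromatic nitrogen, in words 2-fluorophenyl in place of 3-methylphenyl on an aromatic nitrogen.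

Within the data shown here, two measured steps bear on this. The closer guide is a 2.1-fold lower number from compound 1 to compound 2 (0.32 log units; beyond the scatter), which came with 3-methylphenyl in place of 2-methylphenyl at that same nitrogen. It is modest, and no fluorophenyl has been measured there. The other is a 1.5-fold higher number from compound 2 to compound 3 (0.16 log units; within the scatter), which came with fluoro in place of hydrogen on an aromatic carbon. Compound 4 keeps that fluoro, so this step adds little. A small rise in this assay is therefore expected, probably no larger than the scatter. The estimated change is a 1.2-fold higher number from compound 3 to compound 4 (0.07 log units; within the scatter). For compound 4 the expected value is 8000 nM, with an estimated range of 3500 nM to 18000 nM.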

Compound 4, half-maximal inhibitory concentration: 8510 nM
Compound 4: the middle estimate sits 1.1-fold (0.03 log units) below what was measured, and the stated range covers the measured number.
By their numbers in this assay, from the lowest: compounds 2, 3, 4 and 1 (each within the scatter of the next, the first and the last beyond it).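

In this assay, 2-fluorophenyl in place of 3-methylphenyl on the aromatic nitrogen gives a 1.2-fold higher number from compound 3 to compound 4 (0.10 log units; within the scatter), so the two groups cannot be told apart in this test. Compound 4 is the only compound shown with a fluorine rather than a methyl on the phenyl ring at this nitrogen, and on this fluoro-bearing core, that exchange between two groups with the same number of heavy atoms leaves the number within the usual scatter. No independent measurement is available to explain this result.

Going by these compounds, how 2-fluorophenyl behaves on the core without the fluoro remains open, since compound 4 differs from compounds 1 and 2 in more than one place. Also open, on these data alone, is whether an amine or a carboxylic acid on that phenyl ring would shift the number beyond the scatter.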